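A few compounds are considered here, and "the series" means these few. Any claim that something is new, unique, unknown or untested is made for them only; others in the source may bear on it.

Compounds measured in an ADME assay on Vero cells (Chlorocebus sabaeus) for cytotoxicity, read by resazurin assay, with a stated time of 3 days (a higher number here means a weaker inhibitor, a lower number a stronger inhibitor), so far:

Compound 1 `CCN(CC)c1cc2[nH]c(C3CCCCC3)nc2cc1NC(=O)c1ccc(OC(F)F)cc1` — in this assay compound 1 gives > 100 ug/mL, which is a limit of the assay rather than a number.
Compound 2 `CCCNC(=O)Nc1cc2nc(C3CCCCC3)[nH]c2cc1N(CC)CC` — in this assay compound 2 gives > 100 ug/mL, again a limit and not a number.

Compound 2 therefore stands at the upper limit of this assay, and so does compound 1; both values sit at the limit of > 100 ug/mL in this assay, at which 2 of the 2 values shown sit. Within the data shown here, the one step between the measured compounds, a step that the two limits leave unreadable from compound 1 to compound 2, is unreadable from these two limits, so neither its size nor its direction is known.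

Compound 3 `CCc1ccc(C(=O)Nc2cc3nc(C4CCCCC4)[nH]c3cc2N(CC)CC)cc1` differs from compound 2 in one place: 4-ethylphenyl in place of propylamino on a carbonyl carbon. Among the measured compounds shown here, the only measured step that bears on this change is the unreadable one from compound 1 to compound 2, which involves the same carbonyl position, so no size of step can be derived from it. With both neighbours at the limit, no step beyond the scatter is expected in this assay, and compound 3 is expected to return a limit as well, a step that the limit leaves unreadable from compound 2 to compound 3.

On that basis compound 3 is estimated at 120 ug/mL, within a range from 40 ug/mL to 400 ug/mL.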

Compound 3, half-maximal inhibitory concentration: > 100 ug/mL
Compound 3 ended at the assay's limit; the forecaster's own chance of this, stated with the estimate: 80%; the middle value does not contradict the limit.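

In this assay compound 3 gives > 100 ug/mL, which is a limit and not a number. No new step can be read among compound 1, compound 2 and compound 3, because all three stand at the same limit: the limit of > 100 ug/mL in this assay, at which 3 of the 3 values shown sit. The compounds shown leave open how far their true values lie past that limit, and whether the changes between them shift those values at all.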